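Benzyl substituent changes on the nucleoside series: compound 3

The source may hold more compounds than are shown below. What is called first, only, known or untested is meant among the compounds shown, and "the series" means these compounds.

For the measured compounds named here, compound 2 `OC[C@H]1O[C@@H](n2cnc3c(NCc4ccccc4Br)ncnc32)[C@H](O)[C@@H]1O` gives 6600 nM in a functional assay on HL-60 cells (Homo sapiens) for antiproliferative activity, with a stated time of 72 h (on this read-out lower numbers stand for stronger inhibition and higher numbers for weaker inhibition), the higher of the two numbers measured so far. Going by the values given here, compound 1 `OC[C@H]1O[C@@H](n2cnc3c(NCc4ccccc4F)ncnc32)[C@H](O)[C@@H]1O` gives 3200 nM in this assay, and the only measured step is a 2.1-fold higher number from compound 1 to compound 2 (0.31 log units; beyond the scatter). Compound 3 `COc1cc(CNc2ncnc3c2ncn3[C@@H]2O[C@H](CO)[C@@H](O)[C@H]2O)cc(OC)c1` differs from compound 2 in another way: 3,5-dimethoxyphenyl in place of 2-bromophenyl on a saturated chain carbon bound to a nitrogen on an aromatic ring. Among the compounds with values here, no measured step swaps a halogen for methoxy groups, so that single step serves only as a rough scale for how far this part of the molecule moves the number. For compound 3 the expected step is a 1.5-fold lower number from compound 2 to compound 3 (0.17 log units; within the scatter), near the measured step's size with no direction preferred. Compound 3 is estimated at 4500 nM, within 1200 nM to 17000 nM.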

Compound 3, half-maximal inhibitory concentration: 20200 nM
Beside the measured number, compound 3's estimate is 4.5-fold (0.65 log units) below it, and the stated range ends below it.
By their numbers in this assay, from the lowest: compound 1; then compound 2; then compound 3.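

Replacing a halogenated phenyl with 3,5-dimethoxyphenyl at this position weakens inhibition in this assay, with a 3.1-fold higher number from compound 2 to compound 3 (0.49 log units; beyond the scatter) and a 6.3-fold higher number from compound 1 to compound 3 (0.80 log units; beyond the scatter) on the same change. Both steps are larger than the bromo-for-fluoro step, so the choice of aryl group moves the number further than the choice of halogen does among these compounds. Nothing available explains this loss.

Open, going by these compounds, is whether one methoxy group would give a similar number. Also open, on these data alone, is how an amine or a carboxylic acid on the phenyl ring would compare.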